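A Second Chloro Group on Two Related Cores

The source may report more compounds than this note shows. Statements on the series, on what has been measured and on what is new or still open speak of the compounds shown alone.

Of the compounds shown here, three have been measured in a functional assay on SK-MEL-2 cells (Homo sapiens) for cytotoxicity, read by sulforhodamine B assay, with a stated time of 48 h; a higher number here means a weaker inhibitor of growth, a lower number a stronger inhibitor of growth. Compound 1 `ClCc1ccccc1Cn1cnc2c(Cl)nc(Cl)nc21` gives 2180 nM in this assay. Compound 2 `ClCc1ccccc1Cn1cnc2c(Cl)ncnc21` carries one chloro group fewer than compound 1. In this assay compound 2 gives 2750 nM. The step of a 1.3-fold lower number from compound 2 to compound 1 (0.10 log units; within the scatter) corresponds to the change (chloro in place of hydrogen on an aromatic carbon). Compound 3 `ClCc1cccc(Cn2cnc3ncnc(Cl)c32)c1` has the same atoms as compound 2 joined differently; the difference between the two cores is not broken down here. In this assay compound 3 gives 5750 nM, the highest of the three numbers, and its gap to compound 2 and to compound 1 lies beyond the scatter in each case.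

Compound 4 `ClCc1cccc(Cn2cnc3nc(Cl)nc(Cl)c32)c1` has not yet been measured in this assay. It differs from compound 3 by chloro in place of hydrogen on an aromatic carbon, which is the same change as that from compound 2 to compound 1, made on the core of compound 3 instead. This change is seen twice among the compounds here, once measured and once not.

Because the step of a 1.3-fold lower number from compound 2 to compound 1 (0.10 log units; within the scatter) lies within the scatter, compound 4 is expected to give 4500 nM in this assay. The estimate for compound 4 is expected to fall between 2000 nM and 10000 nM. For the measured compounds named here, the expected step from the measured compound is a 1.3-fold lower number from compound 3 to compound 4 (0.11 log units; within the scatter), small and resting only on the single earlier example of this change.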

Compound 4, concentration for 50% growth inhibition: 1770 nM
Compound 4: the middle estimate sits 2.5-fold (0.41 log units) above what was measured, and the stated range ends above it.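

In this assay, chloro in place of hydrogen on the core of compound 3 gives a 3.2-fold lower number from compound 3 to compound 4 (0.51 log units; beyond the scatter), a step clear of the scatter, whereas the earlier step on the other core could not be told from the scatter. Even so, the sizes of the two steps cannot be told apart when they are set side by side: the same change on two cores in this assay, a 1.3-fold lower number (0.10 log units; within the scatter) from compound 2 to compound 1 and a 3.2-fold lower number (0.51 log units; beyond the scatter) from compound 3 to compound 4, 2.6-fold (0.41 log units) apart, within the scatter of two such steps This is compatible with the change carrying over from one core to the other at much the same size, but two pairs are too few to establish that, and they show neither how the change would behave on a third core nor why the number is lower on this one.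

At the place between two ring nitrogen atoms, the compounds shown carry only hydrogen or chloro, which leaves open what an amine, a methoxy group or a longer chain would do there. From the compounds shown here alone, the chloro group meta to that place is present in all four compounds, so what happens when it gives way to an amine or to hydrogen also remains open.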